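Plasma protein binding across a urea series

This account rests on a few compounds, and the source may have more. Where it says the series, first, only, none or still open, it means among the compounds named here.

Measured so far:
- compound 1 `Nc1nccc(N2CC[C@H](NC(=O)Nc3ccc(Cl)c(C(F)(F)F)c3)C2)n1`: 99.4%
- compound 2 `CNc1nccc(N2CC[C@H](NC(=O)Nc3ccc(C)c(Cl)c3)C2)n1`: 98.6%

In an ADME assay on a cell-free system (plasma, Mus musculus) for protein binding, compound 1 gives 99.4% and compound 2 gives 98.6%. Compound 2 stands with the highest unbound fraction of the two; compound 1 sits beyond the scatter from it, with a markedly lower unbound fraction. Within the data shown here, no pair of measured compounds differs in one place, so no single step is known.

Compound 3 `CNc1nccc(N2CC[C@H](NC(=O)Nc3cccc(C#N)c3)C2)n1` is the next compound to be measured. Relative to compound 2 its difference is 3-cyanophenyl in place of 3-chloro-4-methylphenyl on an amide-type nitrogen.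

Among the measured compounds shown here, with no measured step of this kind available, the expectation rests on the two values shown and on the change itself. A step from compound 2 to compound 3 toward lower plasma protein binding, beyond the scatter, is expected: a 2.9-fold higher unbound fraction from compound 2 to compound 3 (0.46 log units; beyond the scatter). For compound 3 the estimated value in this assay is 96%, within a range from 92% to 98.5%.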

Compound 3, plasma protein binding: 91.5%
The estimate for compound 3 lay 2.1-fold (0.33 log units) (unbound fraction) below the measured number, and the stated range ends above it.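

In this assay the aryl group on the amide-type nitrogen now has a measured single step: 3-cyanophenyl in place of 3-chloro-4-methylphenyl gives a 6.1-fold higher unbound fraction from compound 2 to compound 3 (0.78 log units; beyond the scatter) and shows that this place alone can shift the free fraction well beyond the scatter. The two groups match in heavy atoms and both keep the carbon-only aromatic ring, while the entering group brings a triple bond and a hydrogen-bond acceptor. Nothing measured here ties the shift to any property of either group.

Going by these compounds, this single step changes the chlorine, the methyl and the nitrile together, and their separate shares remain open. Also open, on these data alone, is how a carboxylic acid or an amine on this phenyl ring would read in this assay and whether the shift would extend further.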